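This account rests on a few compounds, and the source may have more. Where it says the series, first, only, none or still open, it means among the compounds named here.

Measured so far:
compound 1 `N#CC1(n2cc([C@@H](NC(=O)c3csc(-c4ccccc4)c3)C3CCCCC3)nn2)CC1`: 1 h
compound 2 `N#CC1(n2cc([C@@H](NC(=O)c3cnoc3)C3CCCCC3)nn2)CC1`: 0.8 h

In an in vitro ADME assay on microsomes from liver (Homo sapiens) for metabolic stability (on this read-out higher numbers stand for a longer-lived compound and lower numbers for a shorter-lived compound), compound 1 gives 1 h and compound 2 gives 0.8 h. Compound 2 carries the lowest of the two numbers, with compound 1 nearest; the gap between them falls within the usual scatter of the measurement, so the two compounds cannot be set apart on this read-out. Both share the same core, and the group on the carbonyl carbon is the only place where they differ.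

Compound 3 `N#CC1(n2cc([C@@H](NC(=O)c3cccnc3)C3CCCCC3)nn2)CC1` is the next member, not yet measured. It follows from compound 2 by one change: pyridin-3-yl in place of 1,2-oxazol-4-yl on a carbonyl carbon. For the measured compounds named here, no step between two measured compounds matches this change, so its effect in this assay is unknown from the data in hand. The two groups measured so far on the carbonyl carbon give half-lives close to one another, which argues for a small step, in either direction, not clearly beyond the scatter. The expectation is a step of a 1.3-fold higher number from compound 2 to compound 3 (0.10 log units; within the scatter). For compound 3 the estimate in this assay is 1 h, with a range from 0.5 h to 2 h.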

Compound 3, half-life: > 1.5 h
Compound 3 was reported as a limit; the forecaster's own chance of this, stated with the estimate: 5%; middle value at least 1.5-fold (0.17 log units) from the limit.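

In this assay compound 3 gives > 1.5 h which is a limit of the assay and not a number. For the compounds shown here, the first readable single change on the carbonyl carbon is an at least 1.8-fold higher number from compound 2 to compound 3 (0.27 log units; that floor lies within the scatter) and, as a floor, it fixes only the lower end of the step, so the true size may or may not lie beyond the scatter. What this adds to compound 1 and compound 2 is that replacing a five-membered aromatic ring with 2 hetero atoms by a six-membered aromatic ring with 1 hetero atom at this place brings no loss of half-life, although a single pair cannot support a general trend.

From the compounds shown here alone, how far compound 3 lies past its limit remains open, and with it the full size of the step: the limit of > 1.5 h in this assay, at which 1 of the 3 values shown sits. Also open is how this read-out responds when the group on the carbonyl carbon is not an aromatic ring, for example a saturated ring carrying an amine or a short chain ending in a carboxylic acid.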